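The compounds below may be only part of what the source reports. "The series", "measured", "known", "first", "only" and "open" are said of these compounds alone.

Compound 1, `Cc1ccc(NCc2cn(-c3ccccc3)nc2-c2ccc(C)cc2)cc1`, was examined in an ADME assay on BHK-21 cells (Mesocricetus auratus) for cytotoxicity, read by MTT assay, with a stated time of 72 h; a higher number here means that more compound is tolerated, a lower number that less compound is tolerated. In this assay compound 1 reaches only the limit > 100000 nM. Compound 2, `Cc1ccc(NCc2cn(-c3ccccc3)nc2-c2ccccc2)cc1`, differs from compound 1 by hydrogen in place of methyl on an aromatic carbon. In this assay compound 2 also reaches only the limit > 100000 nM. The step that the two limits leave unreadable from compound 1 to compound 2 therefore cannot be sized. Compound 3, `Cc1ccc(-c2nn(-c3ccccc3)cc2CNc2ccc(Cl)cc2)cc1`, differs from compound 1 by chloro in place of methyl on an aromatic carbon. In this assay compound 3 likewise reaches only the limit > 100000 nM, so the step that the two limits leave unreadable from compound 1 to compound 3 is unreadable as well. What the three measured compounds share is the limit of > 100000 nM in this assay, at which 3 of the 3 values shown sit.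

Compound 4, `Clc1ccc(NCc2cn(-c3ccccc3)nc2-c2ccccc2)cc1`, is not yet measured. It differs from compound 3 by hydrogen in place of methyl on an aromatic carbon, the same change as from compound 1 to compound 2, at the same place. Because the limit of > 100000 nM in this assay, at which 3 of the 3 values shown sit, holds for all three measured compounds, compound 4 is expected to tolerate compound at a similar level, with an expected step that the limit leaves unreadable from compound 3 to compound 4. Compound 4 is estimated to give about 150000 nM in this assay, most likely reported again as a limit, with a range from 60000 nM to 400000 nM.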

Compound 4, half-maximal cytotoxic concentration: > 100000 nM
Compound 4: no number, only a limit; the forecaster's own chance of this, stated with the estimate: 85%; the middle value does not contradict the limit.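

In this assay compound 4 gives > 100000 nM, which is a limit and not a number. The steps to compound 4 from compound 3 and from compound 2 therefore cannot be read. The compounds shown leave open at what concentration any of them becomes cytotoxic, and whether these changes matter at all, since all share one result: the limit of > 100000 nM in this assay, at which 4 of the 4 values shown sit.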